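Chloro for methyl on the diisopropyl dithiocarbamate chromone

A few compounds are considered here, and "the series" means these few. Any claim that something is new, unique, unknown or untested is made for them only; others in the source may bear on it.

Among the measured compounds of this series, compound 3 `Cc1ccc2c(=O)c(CSC(=S)N(C(C)C)C(C)C)coc2c1` gives 1400 nM in a functional assay on HeLa cells (Homo sapiens) for antiproliferative activity, read by MTT assay, with a stated time of 72 h (on this read-out lower numbers stand for stronger inhibition and higher numbers for weaker inhibition), the highest of the two numbers shown; the nearest is compound 2 `O=c1c(CSC(=S)N2CCCCC2)coc2cc(Cl)ccc12`, which in this assay gives 440 nM. Compound 1 `Cc1ccc2c(=O)c(CSC(=S)N3CCCCC3)coc2c1` reaches only a limit of the assay, > 25000 nM, and gives no number (the limit of > 25000 nM in this assay, at which 1 of the 3 values shown sits). Compound 4 `CC(C)N(C(=S)SCc1coc2cc(Cl)ccc2c1=O)C(C)C` is the next member, not yet measured. It differs from compound 3 in one place: chloro in place of methyl on an aromatic carbon. The same change has been made once before, and there the step was large: an at least 56-fold lower number from compound 1 to compound 2 (1.75 log units; beyond the scatter). That step rests on a limit, so its full size is not known, yet its direction is clear. The other change seen, an at least 17-fold lower number from compound 1 to compound 3 (1.25 log units; beyond the scatter), shows that the diisopropylamino group already brought compound 3 below the limit. For compound 4 the author therefore expects a lower number than compound 3, a step of about a 9.3-fold lower number from compound 3 to compound 4 (0.97 log units; beyond the scatter). He estimates compound 4 at 150 nM in this assay, with a range from 40 nM to 800 nM.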

Compound 4, half-maximal inhibitory concentration: > 25000 nM
Compound 4 was reported as a limit; the forecaster's own chance of this, stated with the estimate: 5%; middle value at least 160-fold (2.22 log units) from the limit.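

In this assay, the effect of chloro in place of methyl on an aromatic carbon now proves to depend on the group on the thiocarbonyl carbon, with an at least 17-fold higher number from compound 3 to compound 4 (1.25 log units; beyond the scatter), against the opposite direction in the earlier pair: the same change on two cores in this assay, an at least 56-fold lower number (1.75 log units; beyond the scatter) from compound 1 to compound 2 and an at least 17-fold higher number (1.25 log units; beyond the scatter) from compound 3 to compound 4, at least 1000-fold (3.00 log units) apart, beyond the scatter of two such steps.

Diisopropylamino in place of piperidin-1-yl on a thiocarbonyl carbon likewise reverses its direction, with an at least 56-fold higher number from compound 2 to compound 4 (1.75 log units; beyond the scatter): the same change on two cores in this assay, an at least 17-fold lower number (1.25 log units; beyond the scatter) from compound 1 to compound 3 and an at least 56-fold higher number (1.75 log units; beyond the scatter) from compound 2 to compound 4, at least 1000-fold (3.00 log units) apart, beyond the scatter of two such steps.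

Among these four, only methyl with diisopropylamino and chloro with piperidin-1-yl give a number, while compound 1 and compound 4 both stand at a limit: the limit of > 25000 nM in this assay, at which 2 of the 4 values shown sit.

From the compounds shown here alone, whether this dependence extends to fluoro or bromo on the aromatic carbon, or to diethylamino or morpholin-4-yl on the thiocarbonyl carbon, stays open. Going by these compounds, the full size of each step, resting on a limit, also remains unknown.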